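The source may report more compounds than this note shows. Statements on the series, on what has been measured and on what is new or still open speak of the compounds shown alone.

Measured compounds:
- compound 1 `CS(=O)(=O)Oc1c(C(=O)NCc2ccc(F)cc2)nc(Br)c2cccnc12` — "not determined" (no result reported) in a functional assay on MCF7 cells (Homo sapiens) for cytotoxicity, read by MTT assay, with a stated time of 72 h; a higher number here means a weaker inhibitor, a lower number a stronger inhibitor
- compound 2 `O=C(NCc1ccc(F)cc1)c1nc(Br)c2cccnc2c1NCc1ccc(F)cc1` — "not determined" (no result reported) in this assay
- compound 3 `O=C(NCCCNc1c(C(=O)NCc2ccc(F)cc2)nc(Br)c2cccnc12)c1ccccc1` — 2000 nM

Within the data shown here, compound 3 is the only member of the series with a number in this assay; the other two entries carry no result, so there is no measured step to compare it against and nothing to rank it above or below. Its half-maximal inhibitory concentration in this assay, 2000 nM, therefore stands alone as the reference point.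

The next compound, compound 4 `NCCCCCCNc1c(C(=O)NCc2ccc(F)cc2)nc(Br)c2cccnc12`, differs from compound 3 in a single place: 3-aminopropyl in place of benzamido on a saturated chain carbon, three bonds along the chain from a nitrogen on an aromatic ring. The benzamido group at the end of the chain is exchanged for a shorter 3-aminopropyl group, and the chain carries a free amine rather than an amide at its end.

Among the measured compounds shown here, with no measured step, the size of the expected change rests on the structural exchange alone. A modest shift beyond the scatter cannot be ruled out in either direction, but the expectation is a small weakening. The step from compound 3 to compound 4 is expected to be a 1.5-fold higher number from compound 3 to compound 4 (0.18 log units; within the scatter). Compound 4 is estimated at 3000 nM, within a range of 800 nM to 12000 nM.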

Compound 4, half-maximal inhibitory concentration: 2000 nM
Compound 4: the middle estimate sits 1.5-fold (0.18 log units) above what was measured; the range from low to high includes it.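

In this assay, 3-aminopropyl in place of benzamido on a saturated chain carbon, three bonds along the chain from a nitrogen on an aromatic ring, gives no change at the digits printed from compound 3 to compound 4 (within the scatter). Among these compounds, this is the first readable step, and it shows that at this position the read-out does not separate an end group carrying a six-membered aromatic ring and a double bond outside aromatic rings from one with no ring, while the shared core stays unchanged. With a single pair, this holds only for this exchange, and no measurement on hand bears on why the two compounds read alike.

Still open, from the compounds shown here alone, is whether the chain length or the end group matters more in this pair, since the exchange alters both at once: a benzamido group on a longer chain, or an amine on the shorter chain of compound 3, would pull the two apart. Also open, going by these compounds, is how a carboxylic acid or a dimethylamino group at the chain end would read, and whether any change at this position moves the value beyond the usual scatter.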